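Amide substituent variation on a shared core

This account rests on a few compounds, and the source may have more. Where it says the series, first, only, none or still open, it means among the compounds named here.

Compound 1 `COc1ccc(-c2cn3cc(C4=CCN(S(=O)(=O)CCc5ccccc5)CC4)ccc3n2)cc1OC`: 7690 nM in a functional assay on A549 cells (Homo sapiens) for antiproliferative activity, read by MTT assay, with a stated time of 48 h; a lower number here means a stronger inhibitor, a higher number a weaker inhibitor
Compound 2 `COc1ccc(-c2cn3cc(C4=CCN(C(=O)C5CC5)CC4)ccc3n2)cc1OC`: 9140 nM in this assay

Compound 2 holds the higher of the two numbers, yet the step of a 1.2-fold higher number from compound 1 to compound 2 (0.08 log units; within the scatter) lies within the scatter, so the two stand together. Compound 3 `COc1ccc(-c2cn3cc(C4=CCN(C(=O)c5cccs5)CC4)ccc3n2)cc1OC` differs from compound 2 by thiophen-2-yl in place of cyclopropyl on a carbonyl carbon. Going by the values given here, the only measured step on this part of the molecule, a 1.2-fold higher number from compound 1 to compound 2 (0.08 log units; within the scatter), was within the scatter, and no data on the entering group exist. No step beyond the scatter is therefore expected in this assay; the estimated step is a 1.1-fold lower number from compound 2 to compound 3 (0.06 log units; within the scatter). For compound 3 the estimate is 8000 nM, with a range from 3000 nM to 20000 nM.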

Compound 3, half-maximal inhibitory concentration: 5200 nM
Compound 3: the middle estimate sits 1.5-fold (0.19 log units) above what was measured; the range from low to high includes it.
By their numbers in this assay, from the lowest: compounds 3, 1 and 2 (each within the scatter of the next).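

In this assay, an aromatic ring on the carbonyl carbon gives no step beyond the scatter: thiophen-2-yl in place of cyclopropyl gives a 1.8-fold lower number from compound 2 to compound 3 (0.24 log units; within the scatter), and the change of the whole substituent on the ring nitrogen gives a 1.5-fold lower number from compound 1 to compound 3 (0.17 log units; within the scatter). Phenethylsulfonyl, cyclopropylcarbonyl and (thiophen-2-yl)carbonyl therefore stand together at this position, and the entering sulfur-containing aromatic ring does not separate compound 3 from the other two. No evidence is available that bears on these numbers.

On these data alone, whether an amine or a carboxylic acid on the carbonyl carbon would move the number beyond the scatter remains open. The same holds for a phenyl ring or a longer chain there.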